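This account rests on a few compounds, and the source may have more. Where it says the series, first, only, none or still open, it means among the compounds named here.

Working notes on the series. Compound 1 `CCCC[C@@H](CCn1cncn1)c1ccccc1` gives 40.8 ug/mL in an ADME assay on HEp-2 cells (Homo sapiens) for cytotoxicity, read by MTT assay, with a stated time of 3 days; on this read-out higher numbers stand for lower toxicity in this test and lower numbers for higher toxicity in this test. For the measured compounds named here, compound 2 `CCCC[C@@H](CCn1cncn1)c1ccc(Cl)cc1` gives 17 ug/mL, and the step of a 2.4-fold lower number from compound 1 to compound 2 (0.38 log units; beyond the scatter) is the only substituent change in hand. Compound 3 `CCCC[C@H](CCn1cncn1)c1ccc(F)cc1` gives 38.5 ug/mL, the second highest of the three numbers, within the scatter of compound 1 and beyond the scatter against compound 2. Compound 4 `CCCC[C@@H](CCn1cncn1)c1ccc(F)cc1` differs from compound 3 as follows: the two compounds have the same atoms and bonds and differ only in configuration as drawn: 1 of 1 stereo elements differ; a stereocentre at a saturated chain carbon is drawn R in compound 3 and S in compound 4. Going by the values given here, no measured step turns on configuration alone; the step of a 2.4-fold lower number from compound 1 to compound 2 (0.38 log units; beyond the scatter) concerns a substituent and does not bear on this change. With nothing pointing either way, no shift beyond the scatter is expected, and compound 4 is estimated at 36 ug/mL with a range of 18 ug/mL to 70 ug/mL, an expected step of a 1.1-fold lower number from compound 3 to compound 4 (0.03 log units; within the scatter).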

Compound 4, half-maximal cytotoxic concentration: 36 ug/mL
For compound 4 middle estimate and measured number coincide at the digits printed, and the stated range covers the measured number.
By their numbers in this assay, from the lowest: compound 2; then compounds 4, 3 and 1 (each within the scatter of the next).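

In this assay, the stereocentre at the saturated chain carbon makes no difference beyond the scatter (a 1.1-fold lower number from compound 3 to compound 4 (0.03 log units; within the scatter)), and this pair reads configuration alone: the fact that compounds 3 and 4 differ only in the configuration as drawn. Fluoro in place of hydrogen also stays within the scatter (a 1.1-fold lower number from compound 1 to compound 4 (0.05 log units; within the scatter)), whereas fluoro in place of chloro does not (a 2.1-fold higher number from compound 2 to compound 4 (0.33 log units; beyond the scatter)). Among these three aromatic substituents, chloro alone stands apart.

On these data alone, it remains open whether configuration is equally silent with chloro on the aromatic ring. As far as these compounds go, how an amine, a methoxy group or a longer chain would read in this assay also remains open.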